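The source may hold more compounds than are shown below. What is called first, only, known or untested is meant among the compounds shown, and "the series" means these compounds.

Measured in a functional assay on cells (T-cell line, Homo sapiens) for inhibition; a lower number here means a stronger inhibitor, a higher number a weaker inhibitor:
- Compound 1 `COc1ccc(CCCN2CCC(COCc3ccc(Cl)cc3)CC2)cc1`: 500 nM
- Compound 2 `COc1ccc(CCCN2CCC(COCc3ccc(Cl)c(Cl)c3)CC2)cc1`: 200 nM
- Compound 3 `CN1CCC(COC(c2ccccc2)c2ccccc2)CC1`: > 20000 nM

Compound 3 stands at > 20000 nM, which is a limit of the assay and not a number.

Compound 4 `COc1cccc(CCCN2CCC(COC(c3ccccc3)c3ccccc3)CC2)c1` differs from it as follows: 2-(3-methoxyphenyl)ethyl in place of hydrogen on a saturated chain carbon bound to an amine nitrogen in a ring. That places 2-(3-methoxyphenyl)ethyl on a saturated chain carbon bound to an amine nitrogen in a ring.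

Among the measured compounds shown here, the only measured step, a 2.5-fold lower number from compound 1 to compound 2 (0.40 log units; beyond the scatter), is modest and concerns a chloro group, so it bears only indirectly. For the measured compounds named here, no measured pair isolates the new change.

A large move to a lower number is expected, since compound 1, which has a methoxyphenyl-ended chain on its ring nitrogen, reads 500 nM. The expected step is an at least 50-fold lower number from compound 3 to compound 4 (1.69 log units; beyond the scatter). For compound 4 the estimated value is 400 nM, with an expected range of 80 nM to 3000 nM.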

Compound 4, half-maximal inhibitory concentration: 1500 nM
The estimate for compound 4 lay 3.8-fold (0.57 log units) below the measured number; the measured number falls inside the stated range.
By their numbers in this assay, from the lowest: compound 2; then compound 1; then compound 4. At a limit, above all of these: compound 3.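

In this assay, 2-(3-methoxyphenyl)ethyl on a saturated chain carbon bound to an amine nitrogen in a ring gives an at least 13-fold lower number from compound 3 to compound 4 (1.12 log units; beyond the scatter), the only step at this position among the compounds shown. This single change moves the series from a limit to a measurable value. Compound 3 is held only as a limit, so the step sets a minimum size and the full size stays unknown: the limit of > 20000 nM in this assay, at which 1 of the 4 values shown sits.

Going by these compounds, whether a shorter or longer chain at this place keeps the gain remains open. So does the part played by the methoxy group, which a hydroxyl or a carboxylic acid in its stead would test.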